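The source may report more compounds than this note shows. Statements on the series, on what has been measured and on what is new or still open speak of the compounds shown alone.

Measured in a functional assay on SMMC-7721 cells (Homo sapiens) for cytotoxicity, read by MTT assay, with a stated time of 72 h; a higher number here means a weaker inhibitor, a lower number a stronger inhibitor:

Compound 1 `NC(=O)N1CCN(C(=S)SCc2cn(Cc3ccc(Cl)cc3)nn2)CC1` reaches only the assay limit, > 128000 nM.
Compound 2 `CCNC(=O)N1CCN(C(=S)SCc2cn(Cc3ccc(Cl)cc3)nn2)CC1` likewise reaches only the limit, > 128000 nM.
Compound 3 `COc1cc(Cn2cc(CSC(=S)N3CCN(C(N)=O)CC3)nn2)cc(OC)c1OC` also reaches only the limit, > 128000 nM.

Among the compounds with values here, compound 3 therefore sits where every value so far sits, namely at the limit of > 128000 nM in this assay, at which 3 of the 3 values shown sit, and no number separates it from the other two. Compound 4 `CCN(C)C(=O)N1CCN(C(=S)SCc2cn(Cc3cc(OC)c(OC)c(OC)c3)nn2)CC1` differs from compound 3 by ethyl(methyl)amino in place of amino on a carbonyl carbon. Within the data shown here, the only step that touches the same amide-type nitrogen, a step that the two limits leave unreadable from compound 1 to compound 2, has no readable size, both ends being limits. Among the measured compounds shown here, no measured step thus gives a direction in this assay, and compound 4 is expected to remain at the limit as well. The expected step is a step that the limit leaves unreadable from compound 3 to compound 4. Compound 4 is estimated at 160000 nM, with a range of 40000 nM to 600000 nM.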

Compound 4, half-maximal inhibitory concentration: > 128000 nM
Compound 4: only a limit was reported; the forecaster's own chance of this, stated with the estimate: 85%; the middle value does not contradict the limit.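

Compound 3 and compound 4 both reach only a limit, so no step can be read between them: the limit of > 128000 nM in this assay, at which 4 of the 4 values shown sit. The compounds shown leave open which change to the shared core, if any, would give a measurable value.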